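This account rests on a few compounds, and the source may have more. Where it says the series, first, only, none or still open, it means among the compounds named here.

Measured so far:
Compound 1 `Cc1n[nH]cc1-c1cccc2c1CCC2c1ncc[nH]1` — in a functional assay on CHO cells for agonist activity at Alpha-1D adrenergic receptor (Homo sapiens), read by FLIPR and calcium flux (a higher number here means that more compound is needed for the effect, a lower number that less compound is needed), compound 1 gives 634 nM.
Compound 2 `Cn1ccc(-c2cccc3c2CCC3c2ncc[nH]2)n1` — compound 2 reaches only the limit > 10000 nM.
Compound 3 `Cn1nccc1-c1cccc2c1CCC2c1ncc[nH]1` — compound 3 likewise sits at the limit > 10000 nM.

Compound 3 therefore stands at the limit of > 10000 nM in this assay, at which 2 of the 3 values shown sit, with no number of its own. Compound 4 `Cc1oncc1-c1cccc2c1CCC2c1ncc[nH]1` differs by 5-methyl-1,2-oxazol-4-yl in place of 1-methyl-1H-pyrazol-5-yl on an aromatic carbon. Within the data shown here, the only readable step onto compound 3 is an at least 15-fold higher number from compound 1 to compound 3 (1.19 log units; beyond the scatter), a large loss; a step that the two limits leave unreadable from compound 2 to compound 3 cannot be sized. Since compound 4 again carries a methyl-bearing five-membered ring on the same carbon, and compound 1 shows a numeric value 634 nM with such a ring, some return toward a measurable number is expected, but with wide uncertainty. The expected step is an at least 5.0-fold lower number from compound 3 to compound 4 (0.69 log units; beyond the scatter). Compound 4 is estimated at 2000 nM, between 400 nM and 10000 nM.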

Compound 4, half-maximal effective concentration: > 10000 nM
Compound 4 gave a limit, no number; the forecaster's own chance of this, stated with the estimate: 35%; middle value at least 5.0-fold (0.69 log units) from the limit.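

In this assay compound 4 reaches > 10000 nM, a limit and not a number. A methyl-bearing five-membered ring on this aromatic carbon therefore does not by itself restore a number, with 5-methyl-1,2-oxazol-4-yl replacing 3-methyl-1H-pyrazol-4-yl giving an at least 15-fold higher number from compound 1 to compound 4 (1.19 log units; beyond the scatter); the steps to compound 4 from compound 2 and compound 3 cannot be read. Of the groups shown at this position, only that of compound 1 gives a number: the limit of > 10000 nM in this assay, at which 3 of the 4 values shown sit.

Still open, as far as these compounds go, is whether the methyl of 3-methyl-1H-pyrazol-4-yl matters, since the 1H-pyrazol-4-yl ring without it does not appear here. From the compounds shown here alone, how an amine or a carboxylic acid on this carbon would read also remains open.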